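This account rests on a few compounds, and the source may have more. Where it says the series, first, only, none or still open, it means among the compounds named here.

Compound 1 `C[C@@H](/N=C(/S)Nc1ccncc1)C(C)(C)C`: 501 nM
Compound 2 `CC(N/C(=C\[N+](=O)[O-])Nc1ccncc1)C(C)(C)C`: 1000 nM
Compound 3 `CC(C)(C)CNC(=O)Nc1cccnc1`: 2000 nM

These three compounds were tested in a functional assay for inhibition, with Rattus norvegicus as the target; a higher number here means a weaker inhibitor, a lower number a stronger inhibitor. There, compound 3 gives 2000 nM. This reading lies within the scatter of the reading for compound 2, so the two cannot be told apart. Compared with compound 1, compound 3 has a higher number, and that gap lies beyond the scatter.

The next compound to be measured is compound 4 `CC(C)(C)NC(=O)Nc1cccnc1`, which differs from compound 3 in one place: tert-butyl in place of neopentyl on an amide-type nitrogen. In words, tert-butyl stands in place of neopentyl on an amide-type nitrogen. Going by the values given here, no pair of measured compounds differs in one place only, so the data offer no direct precedent for this change. The expectation therefore starts from compound 3 at 2000 nM and allows for a modest shift toward a higher number in this assay, with no change beyond the scatter also possible. The expected step is a 1.5-fold higher number from compound 3 to compound 4 (0.18 log units; within the scatter). Compound 4 is estimated at 3000 nM, with an expected range of 1000 nM to 10000 nM.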

Compound 4, half-maximal inhibitory concentration: 2000 nM
For compound 4 the middle estimate is 1.5-fold (0.18 log units) above the measured one; the measured number falls inside the stated range.
By their numbers in this assay, from the lowest: compounds 1, 2, 3 and 4 (each within the scatter of the next, the first and the last beyond it).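

In this assay, going by these compounds alone, tert-butyl in place of neopentyl on an amide-type nitrogen gives no change at the digits printed from compound 3 to compound 4 (within the scatter), the first step in this set in which only one place differs. At this nitrogen, whose other neighbour is the carbonyl carbon, the two groups therefore cannot be told apart, so this exchange of one branched alkyl group for the other leaves the reading unresolved from that of compound 3. Nothing at hand bears on why these two readings coincide.

The compounds shown leave open whether a longer chain, a cyclohexyl ring or a carboxylic acid on the same nitrogen would give a reading beyond the scatter of compound 3. They also leave open whether the same exchange of neopentyl and tert-butyl would give a similar step on the cores of compound 1 or compound 2.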